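Dropping a Chloro Group from an Inactive Amide

The source may report more compounds than this note shows. Statements on the series, on what has been measured and on what is new or still open speak of the compounds shown alone.

Compound 1 `O=C(Nc1cccc(-n2cc(-c3ccncc3)c(-c3ccc(Cl)c(O)c3)n2)c1)Nc1ccc(Cl)c(Cl)c1` gives > 32500 nM in a functional assay on SK-OV-3 cells (Homo sapiens) for inhibition, read by sulforhodamine B assay, with a stated time of 48 h; on this read-out lower numbers stand for stronger inhibition of growth and higher numbers for weaker inhibition of growth.
Compound 2 `COc1cc(-c2nn(-c3cccc(NC(=O)c4ccc(Cl)c(C(F)(F)F)c4)c3)cc2-c2ccncc2)ccc1Cl` gives > 32500 nM in this assay.

Both of these numbers are limits of this assay, not measured values. As far as these compounds go, for compound 2 the reading of > 32500 nM is such a limit, so its true strength is unknown beyond that point. For the measured compounds named here, the same holds for both values shown, since (the limit of > 32500 nM in this assay, at which 2 of the 2 values shown sit), leaving no measured step to learn from.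

Compound 3 `COc1cc(-c2nn(-c3cccc(NC(=O)c4cccc(C(F)(F)F)c4)c3)cc2-c2ccncc2)ccc1Cl` differs from compound 2 in one place: hydrogen in place of chloro on an aromatic carbon, which reads, cut one bond further out, as 4-chloro-3-(trifluoromethyl)phenyl becoming 3-(trifluoromethyl)phenyl. With both measured compounds sitting at the limit, there is no ground to expect a change in this assay beyond the usual scatter, and the expected step that the limit leaves unreadable from compound 2 to compound 3 is accordingly small. Compound 3 is therefore estimated at 40000 nM, with a range from 10000 nM to 150000 nM, and most likely it too will be reported only as a limit.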

Compound 3, concentration for total growth inhibition: > 50000 nM
Compound 3: only a limit was reported; the forecaster's own chance of this, stated with the estimate: 80%; at least 1.2-fold (0.09 log units) between middle value and limit.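

Compound 2 and compound 3 are both reported only as limits in this assay, so the step between them, hydrogen in place of chloro, cannot be read. The compounds shown leave open how strongly any of them inhibits growth, and whether this change matters at all.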